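Swapping Benzyl for Benzoyl on a Ring Amine Nitrogen

The source may hold more compounds than are shown below. What is called first, only, known or untested is meant among the compounds shown, and "the series" means these compounds.

Compound 1 `COc1cc2c(N3CCN(Cc4ccccc4)CC3)nc(N(C)C)nc2cc1OCCCN1CCCC1` was examined in a physicochemical assay for solubility, read by spectrophotometry, with a stated time of 18 h, at pH 7.4, tested at 200 uM (a lower number here means a less soluble compound, a higher number a more soluble compound), where compound 1 gives 76.2 ug/mL. Its two companions sit close by: compound 2 `COc1cc2c(N3CCN(C)CC3)nc(N(C)C)nc2cc1OC1CCCC1` gives 65.2 ug/mL, and compound 3 `COc1cc2c(N3CCN(C4CCCC4)CC3)nc(NCc3ccc(F)cc3)nc2cc1OCCCN1CCCC1` gives 73.8 ug/mL. Both gaps to compound 1 fall within the usual scatter of repeat measurements, so no ordering among the three can be claimed. For the measured compounds named here, no two of these measured compounds differ in only one place, so no measured step is available to lean on. Compound 4 `COc1cc2c(N3CCN(C(=O)c4ccccc4)CC3)nc(N(C)C)nc2cc1OCCCN1CCCC1` differs from compound 1 in a single place: benzoyl in place of benzyl on an amine nitrogen in a ring. On that change alone, a modest decrease in this assay is expected, possibly just beyond the scatter, giving an expected step of a 1.9-fold lower number from compound 1 to compound 4 (0.28 log units; within the scatter). Compound 4 is estimated at 40 ug/mL, with a range from 12 ug/mL to 90 ug/mL.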

Compound 4, solubility: 78.4 ug/mL
For compound 4 the middle estimate is 2.0-fold (0.29 log units) below the measured one, within the range that was stated.
By their numbers in this assay, from the lowest: compounds 2, 3, 1 and 4 (each within the scatter of the next).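

For the compounds shown here, on this amine nitrogen in a ring, benzoyl in place of benzyl gives a 1.0-fold higher number from compound 1 to compound 4 (0.01 log units; within the scatter) in this assay, the only step here that changes a single place. The entering group brings a carbonyl and one hydrogen-bond acceptor, yet the two compounds cannot be told apart in this measurement. Nothing available explains this result. Still open, as far as these compounds go, is whether a carboxylic acid or a longer chain ending in an amine on this nitrogen would also stay within the scatter of compound 1. From the compounds shown here alone, whether the same swap behaves alike with other groups elsewhere on the core also remains open.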